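Removing the Methyl from the Methoxy Group of Compound 3

The source may report more compounds than this note shows. Statements on the series, on what has been measured and on what is new or still open speak of the compounds shown alone.

Measured so far in a functional assay on MDA-MB-231 cells (Homo sapiens) for cytotoxicity, read by MTT assay, with a stated time of 72 h; a higher number here means a weaker inhibitor, a lower number a stronger inhibitor:
compound 1 `Cc1cc(/C=C/c2ccc(O)cc2)[nH]n1` gives 23200 nM;
compound 2 `COc1ccc(/C=C/c2cc(C)n[nH]2)cc1` gives 10700 nM;
compound 3 `COc1ccc(/C=C/C(=O)CC(C)=O)cc1` gives 25000 nM.

Compound 1 and compound 2 share one core and differ only by hydrogen in place of methyl on an oxygen on an aromatic ring; that change produced a 2.2-fold higher number from compound 2 to compound 1 (0.34 log units; beyond the scatter). Compound 3 carries a different core, and the difference between the two cores is not broken down here. Compound 4 `CC(=O)CC(=O)/C=C/c1ccc(O)cc1` has not yet been measured in this assay; it differs from compound 3 by hydrogen in place of methyl on an oxygen on an aromatic ring, the same change as from compound 2 to compound 1, at the same kind of place. Because the earlier step gave a 2.2-fold higher number from compound 2 to compound 1 (0.34 log units; beyond the scatter), a similar weakening is expected for compound 4, though the differing core makes the transfer uncertain. The expected step is a 1.9-fold higher number from compound 3 to compound 4 (0.28 log units; within the scatter). Compound 4 is estimated at 48000 nM, expected to fall between 20000 nM and 115000 nM.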

Compound 4, half-maximal inhibitory concentration: 6800 nM
Compound 4: middle estimate off by 7.1-fold (0.85 log units), on the high side; measured number below the stated range.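

In this assay, replacing methoxy with hydroxy gave a 3.7-fold lower number from compound 3 to compound 4 (0.57 log units; beyond the scatter), so compound 4 is the stronger inhibitor of the pair, whereas the same change weakened the compound on the other core. The two steps run in opposite directions: the same change on two cores in this assay, a 2.2-fold higher number (0.34 log units; beyond the scatter) from compound 2 to compound 1 and a 3.7-fold lower number (0.57 log units; beyond the scatter) from compound 3 to compound 4, 8.0-fold (0.90 log units) apart, beyond the scatter of two such steps

This shows that the effect of this change cannot simply be carried from one core to the other in this series. It does not show why the cores differ, and a single pair on each core gives no general rule.

Still open, on these data alone, is how an ethoxy group or an amine would behave at the same place on each core. Also open, as far as these compounds go, is which direction a third core would follow.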